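The compounds below may be only part of what the source reports. "The series", "measured", "known", "first", "only" and "open" are said of these compounds alone.

Compound 1 `CCCn1c(NC(=O)c2cc3ccccc3n2C)nc2cc(C(N)=O)cc(OC)c21`: > 100000 nM
Compound 2 `COc1cc(C(N)=O)cc2nc(NC(=O)c3ccccn3)n(CCCNC(=O)OCc3ccccc3)c12`: > 100000 nM
Compound 3 `CCn1nc(C)cc1C(=O)Nc1nc2cc(C(N)=O)cc(OC)c2n1CCCNC(=O)C(C)(C)C`: > 100000 nM

Of the compounds shown here, three have so far been tested in an assay for activation of interferon regulatory factor 3 (Homo sapiens), read by a luciferase reporter, with a stated time of 20 h (on this read-out lower numbers stand for an effect already at smaller amounts and higher numbers for an effect only at larger amounts of compound), and none of them gave a number. Compound 1 reached only the limit of the assay, > 100000 nM. Compound 2 likewise reached only the limit, > 100000 nM. Compound 3 also stands at the limit, > 100000 nM, so no number is known for it. Among the measured compounds shown here, the whole set therefore sits at the limit of > 100000 nM in this assay, at which 3 of the 3 values shown sit, and no step between measured compounds can be counted.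

Compound 4 `CCn1nc(C)cc1C(=O)Nc1nc2cc(C(N)=O)cc(OC)c2n1CCCNC(=O)OC(C)(C)C` is the compound yet to be measured in this assay. It differs from compound 3 in a single place: tert-butoxy in place of tert-butyl on a carbonyl carbon, turning the ((tert-butyl)carbonyl)amino group into a (tert-butoxycarbonyl)amino group. For the measured compounds named here, no measured step exists to lean on. Compound 3 itself offers only the limit > 100000 nM as a starting point. The expected step is a step that the limit leaves unreadable from compound 3 to compound 4, nothing beyond the usual scatter. Compound 4 is accordingly estimated at 150000 nM, within a range from 50000 nM to 500000 nM, and most probably the assay will again report only a limit for it.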

Compound 4, half-maximal effective concentration: > 100000 nM
Compound 4: no number, only a limit; the forecaster's own chance of this, stated with the estimate: 85%; the middle value is on the limit's open side.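

Among the compounds shown here, compound 3 and compound 4 both stay at a limit in this assay, so the exchange of tert-butyl for tert-butoxy on a carbonyl carbon gives no step that can be read. The compounds shown leave open whether any structure of this kind would give a measured number at all: the limit of > 100000 nM in this assay, at which 4 of the 4 values shown sit.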